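Pentyl in place of (2-carboxyethyl)carbonyl on compound 3

The source may hold more compounds than are shown below. What is called first, only, known or untested is meant among the compounds shown, and "the series" means these compounds.

Measured so far:
- Compound 1, `N#Cc1cccc(C(=O)Nc2ccc3nc(NC(=O)C4CCCCC4)sc3c2)c1`, in a functional assay on WI-38 VA13 cells (Homo sapiens) for cytotoxicity (on this read-out higher numbers stand for an effect only at larger amounts of compound and lower numbers for an effect already at smaller amounts), compound 1 gives 0.52 ug/mL.
- Compound 2, `CC(C)COC(=O)Nc1ccc2nc(NC(=O)C3CCCCC3)sc2c1`, in this assay compound 2 gives 0.72 ug/mL.
- Compound 3, `O=C(O)CCC(=O)Nc1nc2ccc(NC(=O)c3c(Cl)cccc3Cl)cc2s1`, in this assay compound 3 gives only a limit, > 6.6 ug/mL.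

Compound 3 stands at the limit of > 6.6 ug/mL in this assay, at which 1 of the 3 values shown sits, so no number is known for it, only a limit. Compound 4, `CCCCCNc1nc2ccc(NC(=O)c3c(Cl)cccc3Cl)cc2s1`, differs from compound 3 by pentyl in place of (2-carboxyethyl)carbonyl on a nitrogen on an aromatic ring.

Going by the values given here, the one measured step, a 1.4-fold higher number from compound 1 to compound 2 (0.14 log units; within the scatter), sits at a carbonyl carbon and concerns quite different groups, so it does not bear on the change in compound 4; it only shows that this pair moves within the scatter. Among the compounds with values here, with compound 3 known only as a limit, no measured step tells the direction or size of the move to compound 4, and the expected step of an at least 1.3-fold lower number from compound 3 to compound 4 (0.12 log units; that floor lies within the scatter) is therefore an estimate with wide bounds. Compound 4 is expected to give about 5 ug/mL in this assay, between 1.5 ug/mL and 15 ug/mL.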

Compound 4, half-maximal effective concentration: 0.27 ug/mL
For compound 4 the middle estimate is 19-fold (1.27 log units) above the measured one, outside the stated range (below it).
By their numbers in this assay, from the lowest: compounds 4, 1 and 2 (each within the scatter of the next, the first and the last beyond it). At a limit, above all of these: compound 3.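

At this nitrogen on an aromatic ring, pentyl in place of (2-carboxyethyl)carbonyl gives an at least 24-fold lower number from compound 3 to compound 4 (1.38 log units; beyond the scatter), the only step shown here that lies beyond the scatter. Going by these compounds alone, what sits on this nitrogen can therefore matter greatly in this assay, whereas the one earlier step, at a different place, showed no change larger than the scatter. The direction of the new step is clear, but its full size is not, as the figure for compound 3 is a limit and not a number: the limit of > 6.6 ug/mL in this assay, at which 1 of the 4 values shown sits.

The change replaces the whole group at once, so the compounds shown cannot separate the loss of the carbonyl on this nitrogen from the loss of the carboxylic acid at the end of the chain. A hexanoyl group, which keeps the carbonyl without the acid, or a pentyl chain ending in an amine would begin to address this.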